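A chloro to iodo step in a small series

This account rests on a few compounds, and the source may have more. Where it says the series, first, only, none or still open, it means among the compounds named here.

Compound 1 `CSc1ccc(-c2noc(CN3N=N[C@@H]4C(=O)N(c5ccccc5)C(=O)[C@@H]43)n2)cc1`: > 100 ug/mL (a limit)
Compound 2 `COc1ccc(-c2noc(CN3N=N[C@@H]4C(=O)N(c5ccccc5)C(=O)[C@@H]43)n2)cc1`: > 100 ug/mL (a limit)
Compound 3 `O=C1[C@H]2N=NN(Cc3nc(-c4ccc(Cl)cc4)no3)[C@H]2C(=O)N1c1ccccc1`: 49.5 ug/mL

Going by the values given here, in an ADME assay on L6 cells (Rattus norvegicus) for cytotoxicity, read by resazurin assay, with a stated time of 72 h (on this read-out higher numbers stand for weaker inhibition and lower numbers for stronger inhibition), compound 3 gives 49.5 ug/mL, the only true number in the set. The other two compounds rest on (the limit of > 100 ug/mL in this assay, at which 2 of the 3 values shown sit).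

Compound 4 `O=C1[C@H]2N=NN(Cc3nc(-c4ccc(I)cc4)no3)[C@H]2C(=O)N1c1ccccc1` differs from compound 3 by iodo in place of chloro on an aromatic carbon, para to a large group.

Among the compounds with values here, two measured steps touch that carbon: an at least 2.0-fold lower number from compound 1 to compound 3 (0.30 log units; that floor lies within the scatter), and an at least 2.0-fold lower number from compound 2 to compound 3 (0.30 log units; that floor lies within the scatter). Neither brings in iodo, and both floors lie within the scatter. Compound 3 at 49.5 ug/mL therefore stays the anchor, and no change beyond the scatter is expected in this assay. The expected step is a 1.2-fold lower number from compound 3 to compound 4 (0.09 log units; within the scatter). The estimate for compound 4 is 40 ug/mL, within an expected range from 15 ug/mL to 100 ug/mL.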

Compound 4, half-maximal inhibitory concentration: 48.6 ug/mL
Beside the measured number, compound 4's estimate is 1.2-fold (0.08 log units) below it; the range from low to high includes it.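

In this assay, the change from 4-chlorophenyl to 4-iodophenyl leaves the read-out in place, with a 1.0-fold lower number from compound 3 to compound 4 (0.01 log units; within the scatter). Iodo gives an at least 2.0-fold lower number from compound 2 to compound 4 (0.31 log units; beyond the scatter) and an at least 2.0-fold lower number from compound 1 to compound 4 (0.31 log units; beyond the scatter), floors that are printed beyond the scatter, whereas those for chloro lay within it. Both steps remain floors, since they start from limits rather than numbers: the limit of > 100 ug/mL in this assay, at which 2 of the 4 values shown sit.

Going by these compounds, the true size of those two steps stays open. So does whether an amine or a carboxylic acid on this aromatic carbon would shift the number at all.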